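A few compounds are considered here, and "the series" means these few. Any claim that something is new, unique, unknown or untested is made for them only; others in the source may bear on it.

Measured so far in a functional assay on cells (Cancer cell lines, Homo sapiens) for inhibition; on this read-out lower numbers stand for stronger inhibition of growth and higher numbers for weaker inhibition of growth:
compound 1, `Cc1cc(-c2nc3n(c2/C=N/NC(=N)N)CCS3)c(C)s1`, gives 13800 nM;
compound 2, `N=C(N)N/N=C/c1c(-c2cccs2)nc2sccn12`, gives 9770 nM;
compound 3, `N=C(N)N/N=C/c1c(-c2ccsc2)nc2sccn12`, gives 14100 nM.

Compound 2 stands at the low end of these three numbers, yet neither neighbour is separated from it by more than the scatter. Among the measured compounds shown here, compound 1 with 13800 nM sits close to compound 2 with 9770 nM, and the one measured step, a 1.4-fold higher number from compound 2 to compound 3 (0.16 log units; within the scatter), is likewise within the scatter. The three compounds therefore show no difference that can be trusted.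

Compound 4, `Cc1cn2c(/C=N/NC(=N)N)c(-c3cccs3)nc2s1`, is the next member. Its change from compound 2 is methyl in place of hydrogen on an aromatic carbon. For the measured compounds named here, no measured step in this set bears directly on it: the only step, from compound 2 to compound 3, exchanges the attachment of the thiophene rather than adding a methyl, and it stayed within the scatter. Going by the values given here, nothing among the measured compounds points to a large effect from a single methyl on the fused ring.

Compound 4 is therefore expected to stay near compound 2, with a step of a 1.0-fold higher number from compound 2 to compound 4 (0.00 log units; within the scatter) in this assay that is not expected to exceed the scatter. The estimate for compound 4 is 9800 nM, within the range 4000 nM to 24000 nM.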

Compound 4, concentration for 50% growth inhibition: 2570 nM
The estimate for compound 4 lay 3.8-fold (0.58 log units) above the measured number; the measured number lies below the stated range.
By their numbers in this assay, from the lowest: compound 4; then compounds 2, 1 and 3 (each within the scatter of the next).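

In this assay, methyl in place of hydrogen gives a 3.8-fold lower number from compound 2 to compound 4 (0.58 log units; beyond the scatter), the only step among these compounds that lies beyond the scatter. The earlier step, thiophen-3-yl in place of thiophen-2-yl, gave a 1.4-fold higher number from compound 2 to compound 3 (0.16 log units; within the scatter) and so showed no trustworthy change, whereas this result shows that the read-out does respond to a change of a single carbon on the aromatic carbon next to the ring sulfur, two ring bonds from the ring nitrogen. Nothing at hand accounts for why this one methyl lowers the number, and the data give no explanation for the size of the step.

The compounds shown leave open whether the lower number belongs to methyl in particular or would also follow from another group on the same carbon, such as ethyl, a chlorine atom, an amine or a carboxylic acid. Among the compounds shown here, they also leave open whether the same methyl would lower the number in the same way with thiophen-3-yl in place of thiophen-2-yl, as in compound 3, since no step of that kind stands among them.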